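The compounds below may be only part of what the source reports. "The series", "measured", "known", "first", "only" and "open" are said of these compounds alone.

Going by the values given here, in a functional assay on MCF7 cells (Homo sapiens), read by MTT assay, with a stated time of 48 h (on this read-out lower numbers stand for stronger inhibition and higher numbers for weaker inhibition), the series so far holds compound 1 `CCn1c(C(=O)NCCCN(C)C)ccc1C(CC)(CC)c1ccc(OCC(=O)C(C)(C)C)c(C)c1` at 340 nM, compound 2 `CCn1c(C(=O)NCCN)ccc1C(CC)(CC)c1ccc(OCC(=O)C(C)(C)C)c(C)c1` at 75 nM and compound 3 `CCn1c(C(=O)NCCN)ccc1C(CC)(CC)c1ccc(OCC(O)C(C)(C)C)c(C)c1` at 5.9 nM. Compound 3 has the lowest number of the three, and its gaps to both others lie beyond the scatter.

Compound 4 `CCn1c(C(=O)N(C)CC(=O)O)ccc1C(CC)(CC)c1ccc(OCC(O)C(C)(C)C)c(C)c1`, not yet measured, differs from compound 3 as follows: (carboxymethyl)(methyl)amino in place of (2-aminoethyl)amino on a carbonyl carbon. In words, this is (carboxymethyl)(methyl)amino in place of (2-aminoethyl)amino on a carbonyl carbon.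

Among the compounds with values here, only one measured step touches this side chain: a 4.5-fold lower number from compound 1 to compound 2 (0.66 log units; beyond the scatter), a modest change beyond the scatter. The other, a 13-fold lower number from compound 2 to compound 3 (1.10 log units; beyond the scatter), is large but lies at the 1-hydroxy-2,2-dimethylpropyl group, which compound 4 keeps unchanged from compound 3. It therefore says little about the new change.

Within the data shown here, no measured compound carries a carboxymethyl group, and every measured compound has a terminal amine, so the evidence is thin. With compound 3 already lowest in the series, a modest to large step towards a higher number is expected in this assay.

The estimate means a 5.1-fold higher number from compound 3 to compound 4 (0.71 log units; beyond the scatter). Compound 4 is expected at 30 nM, with an estimated range of 6 nM to 150 nM.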

Compound 4, half-maximal inhibitory concentration: 25400 nM
Estimate against measurement, compound 4: 850-fold (2.93 log units) below, and the stated range ends below it.
By their numbers in this assay, from the lowest: compound 3; then compound 2; then compound 1; then compound 4.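

In this assay, going by these compounds alone, the group on the carbonyl carbon matters far more than the earlier compounds showed: replacing (2-aminoethyl)amino with (carboxymethyl)(methyl)amino gives a 4300-fold higher number from compound 3 to compound 4 (3.63 log units; beyond the scatter), a much larger step than a 4.5-fold lower number from compound 1 to compound 2 (0.66 log units; beyond the scatter), the only earlier step on this side chain. The 1-hydroxy-2,2-dimethylpropyl group is the same in compound 3 and compound 4, so its presence does not keep the number low once this change is made. Nothing at hand explains the size of the step.

The change combines several differences: the terminal amine leaves, a carboxylic acid enters, the chain is altered, and a methyl replaces the amide hydrogen, so the compounds shown cannot say which of these carries the step. Still open, from the compounds shown here alone, is how a (carboxymethyl)amino group without the methyl, a (2-aminoethyl)(methyl)amino group or a methyl ester of the carboxylic acid would read on the same carbonyl carbon in this assay.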